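The compounds below may be only part of what the source reports. "The series", "measured", "known", "first", "only" and "open" are said of these compounds alone.

Working notes on the series. Three compounds have been run in an in vitro functional assay on HEK293-A cells for positive allosteric modulation of metabotropic glutamate receptor 5 (Homo sapiens), read by fluorescence and calcium flux, with a stated time of 140 s; on this read-out higher numbers stand for an effect only at larger amounts of compound and lower numbers for an effect already at smaller amounts. Compound 1 `O=C(C1CCC1)N1CCCC[C@H]1c1nc(-c2cccc(F)c2)no1` and compound 2 `O=C(c1cccc(F)c1)N1CCCC[C@@H]1c1nc(-c2cccc(F)c2)no1` share one core; compound 3 `O=C(C1CCCCC1)N1CCCC1c1nc(-c2cccc(F)c2)no1` is built on a different core and carries a cyclohexyl group on its carbonyl carbon. In this assay compound 1 gives 700 nM and compound 2 gives 460 nM; these two numbers lie within the scatter of each other. In this assay compound 3 gives 10000 nM, the highest of the three numbers, well beyond the scatter from both compound 1 and compound 2.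

Compound 4 `O=C(c1ccc(F)cc1F)N1CCCC1c1nc(-c2cccc(F)c2)no1` keeps the core of compound 3 and differs only at the carbonyl carbon: 2,4-difluorophenyl in place of cyclohexyl on a carbonyl carbon. For the measured compounds named here, no measured pair isolates this single change, so its size cannot be read off directly. The aryl amide of compound 2 and the cycloalkyl amide of compound 1 sit within scatter of each other, which argues against a large shift on the present core as well. Still, a downward step from compound 3 to compound 4 of roughly a 3.3-fold lower number from compound 3 to compound 4 (0.52 log units; beyond the scatter) is expected, weighted by the high number of compound 3 at 10000 nM. The expected value for compound 4 in this assay is 3000 nM, with a range of 800 nM to 12000 nM.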

Compound 4, half-maximal effective concentration: 10000 nM
For compound 4 the middle estimate is 3.3-fold (0.52 log units) below the measured one; the measured number falls inside the stated range.
By their numbers in this assay, from the lowest: compounds 2 and 1 (each within the scatter of the next); then compounds 3 and 4 (each within the scatter of the next).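

On the core of compound 3, 2,4-difluorophenyl in place of cyclohexyl on a carbonyl carbon gives no change at the digits printed from compound 3 to compound 4 (within the scatter) in this assay. For the compounds shown here, this is the first single-place step at this position, and it shows that the number does not respond to this exchange of a non-aromatic ring for a fluorinated aromatic ring, even with the larger heavy-atom count of the entering group. No supporting data bear on this flat step.

Open, on these data alone, is whether an amine, a carboxylic acid or a longer chain on the carbonyl carbon would move the number on this core at all. Also open is how much of the distance from compounds 1 and 2 belongs to the core, as no pair shown carries the same group on the carbonyl carbon on both cores.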